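Chain length and the cyanoguanidine swap in rat inhibition

The source may report more compounds than this note shows. Statements on the series, on what has been measured and on what is new or still open speak of the compounds shown alone.

Three compounds share a core and carry a cyanoguanidine-type group on a chain. Compound 1 `CC/N=C(/NC#N)NCCCn1nc(-c2ccccc2)ccc1=O` gives, in a functional assay on the whole organism with Rattus norvegicus as the target, at a dose of 100 mg/kg (on this read-out lower numbers stand for less inhibition and higher numbers for more inhibition at the one dose given (going by the name of the read-out)), a reading of 62.9%. Compound 2 `CN(C)/C(=N/CCCn1nc(-c2ccccc2)ccc1=O)NC#N` differs from compound 1 by a group of 8 heavy atoms (4 carbon, 4 nitrogen; no ring) in place of a group of 8 heavy atoms (4 carbon, 4 nitrogen; no ring), on a saturated chain carbon, three bonds along the chain from an aromatic nitrogen, and in this assay compound 2 gives 72.2%. The step of a number 9.3 percentage points higher from compound 1 to compound 2 (within the scatter) is within the scatter. Compound 3 `CC/N=C(/NC#N)NCCCCCn1nc(-c2ccccc2)ccc1=O` has a longer chain; how its core differs from that of compound 1 is not broken down here. In this assay compound 3 gives 48.2%, the lowest of the three, with the gaps to compound 1 and compound 2 both beyond the scatter.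

Compound 4 `CN(C)/C(=N/CCCCCn1nc(-c2ccccc2)ccc1=O)NC#N` is not yet measured. It differs from compound 3 by a group of 8 heavy atoms (4 carbon, 4 nitrogen; no ring) in place of a group of 8 heavy atoms (4 carbon, 4 nitrogen; no ring), on a saturated chain carbon, five bonds along the chain from an aromatic nitrogen; this is the same kind of change as from compound 1 to compound 2, but here the place is five bonds along the chain from the aromatic nitrogen rather than three. Since the earlier step of a number 9.3 percentage points higher from compound 1 to compound 2 (within the scatter) was small, a step of about a number 8.8 percentage points higher from compound 3 to compound 4 (within the scatter) is expected in this assay. Compound 4 is therefore estimated to give 57%, with a range from 40% to 74%.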

Compound 4, a percentage reported as inhibition, in the whole organism at one dose (the size of the read-out at that dose, not a potency): 63.9%
Compound 4: the middle estimate sits 6.9 percentage points below what was measured; low and high end bracket the measured number.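

In this assay, the swap to a group with 1 hydrogen-bond donor in place of one with 2 hydrogen-bond donors, made on the longer chain, gives a number 15.7 percentage points higher from compound 3 to compound 4 (beyond the scatter). Set beside the same swap on the shorter chain, the two steps cannot be told apart, so the change carries over in about the same size and direction: the same change on two cores in this assay, a number 9.3 percentage points higher (within the scatter) from compound 1 to compound 2 and a number 15.7 percentage points higher (beyond the scatter) from compound 3 to compound 4, 6.4 percentage points apart, within the scatter of two such steps. Among these compounds, this rests on just two pairs at a single dose, and only the step on the longer chain stands clear of the scatter, so it does not show that the swap would behave the same way on any other core, nor why it has this effect.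

The compounds shown leave open what the same swap does on a chain longer than that of compound 3. They also leave open how a reading would change with an amine or a carboxylic acid in place of the cyanoguanidine-type group, or what the two groups do at other doses.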